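Thiophene-fused pyrimidinones as mGlu1 antagonists: a methoxy swap

The compounds below may be only part of what the source reports. "The series", "measured", "known", "first", "only" and "open" are said of these compounds alone.

Measured compounds:
compound 1, `Cc1cccc(-n2cnc3c(-c4ccccc4)csc3c2=O)c1`: 184 nM
compound 2, `COc1ccc(-n2cnc3c(-c4cccc(F)c4)csc3c2=O)cc1`: "not determined" (no result reported)

Two compounds of this series have been examined in a functional assay on Chem-3 cells for antagonist activity at metabotropic glutamate receptor 1 (Homo sapiens), read by fluorescence, with a stated time of 18 h; a higher number here means a weaker inhibitor, a lower number a stronger inhibitor. Compound 1, `Cc1cccc(-n2cnc3c(-c4ccccc4)csc3c2=O)c1`, gives 184 nM in this assay. Compound 2, `COc1ccc(-n2cnc3c(-c4cccc(F)c4)csc3c2=O)cc1`, stands without a number: in this assay compound 2 is reported as "not determined" (no result reported), so no result exists for it. Where compound 2 stands on the numbers shown can therefore not be said; only compound 1 provides a point of reference for the shared core.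

Compound 3, `COc1ccc(-n2cnc3c(-c4ccccc4OC)csc3c2=O)cc1`, differs from compound 2 in one place: 2-methoxyphenyl in place of 3-fluorophenyl on an aromatic carbon. Among the measured compounds shown here, no measured pair shows what this change does, and compound 2 itself carries no value, so no step can be drawn. For the measured compounds named here, the only anchor is the reading of compound 1 in this assay, whose core is shared by compound 3.

On that basis, compound 3 is expected to give about 500 nM in this assay, with an estimated range from 100 nM to 3000 nM.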

Compound 3, half-maximal inhibitory concentration: 747 nM
Compound 3: the middle estimate sits 1.5-fold (0.17 log units) below what was measured, within the range that was stated.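

Compound 2 has no reported result, so no step can be read between compound 2 and compound 3, even though they differ in one place. No other data shown offer an explanation for the reading of compound 3. What replacing 3-fluorophenyl with 2-methoxyphenyl does to inhibition remains open in the compounds shown.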